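The source may report more compounds than this note shows. Statements on the series, on what has been measured and on what is new or still open speak of the compounds shown alone.

In a functional assay on HT cells (Homo sapiens) for antiproliferative activity, read by fluorescence, with a stated time of 72 h (a lower number here means a stronger inhibitor of growth, a higher number a weaker inhibitor of growth), compound 3 `CC(C)c1n[nH]c2c(NCc3ccc(-c4ccccn4)cc3)nc(SC[C@H](O)CN)nc12` gives 63 nM. Compound 2 `CCC(O)CSc1nc(NCc2ccc(-c3ccccn3)cc2)c2[nH]nc(C(C)C)c2n1` gives 273 nM. Compound 1 `CSc1nc(NCc2ccc(-c3ccccn3)cc2)c2[nH]nc(C(C)C)c2n1` gives 783 nM.

Compound 3 has the lowest number of the three, and both steps to it are beyond the scatter. Compound 4 `C=CCSc1nc(NCc2ccc(-c3ccccn3)cc2)c2[nH]nc(C(C)C)c2n1` differs from it in one place: vinyl in place of 2-amino-1-hydroxyethyl on a saturated chain carbon bound to a sulfur. Among the measured compounds shown here, two measured steps bear on this change. The step of a 12-fold lower number from compound 1 to compound 3 (1.09 log units; beyond the scatter) and the step of a 4.3-fold lower number from compound 2 to compound 3 (0.64 log units; beyond the scatter) both lowered the number when the 2-amino-1-hydroxyethyl group entered; compound 4 lacks that group and carries only vinyl, so the number is expected to move back up, toward those of compound 1 and compound 2. The expected step is a 7.9-fold higher number from compound 3 to compound 4 (0.90 log units; beyond the scatter). Compound 4 is therefore estimated at 500 nM, within 200 nM to 1500 nM.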

Compound 4, concentration for 50% growth inhibition: 1010 nM
Compound 4: middle estimate off by 2.0-fold (0.31 log units), on the low side; the range from low to high includes it.
By their numbers in this assay, from the lowest: compound 3; then compound 2; then compounds 1 and 4 (each within the scatter of the next).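

In this assay, the allylsulfanyl chain of compound 4 cannot be told apart from the shorter chain of compound 1: a 1.3-fold higher number from compound 1 to compound 4 (0.11 log units; within the scatter). Chain length alone therefore does not go with a lower number in these two compounds. The oxygen-bearing chains do differ from allyl, with a 3.7-fold higher number from compound 2 to compound 4 (0.57 log units; beyond the scatter) and, with the amine present as well, a 16-fold higher number from compound 3 to compound 4 (1.20 log units; beyond the scatter).

Nothing available explains these differences. Open questions are whether a 3-aminopropyl chain, with the amine but no hydroxyl, would match compound 3, and how a carboxylic acid at the chain end would compare.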